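Triazole in place of glycinamide: expected stability of compound 4

A few compounds are considered here, and "the series" means these few. Any claim that something is new, unique, unknown or untested is made for them only; others in the source may bear on it.

Measured compounds and their half-lives in a physicochemical assay for metabolic stability, read by HPLC and mass spectrometry, in phosphate buffer, at 37 degrees C, at pH 7.4; a lower number here means that the compound disappears faster, a higher number that the compound lasts longer:
Compound 1 `CC(C)(O/N=C(\C(=O)N[C@@H]1C(=O)N(S(=O)(=O)O)[C@@H]1CNC(=O)CN)c1csc(N)n1)C(=O)O` gives 149 h.
Compound 2 `CC(C)(O/N=C(\C(=O)N[C@@H]1C(=O)N(S(=O)(=O)O)[C@@H]1CN1CCCCC1=O)c1csc(N)n1)C(=O)O` gives 214 h.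
Compound 3 `CC(C)(O/N=C(\C(=O)N[C@@H]1C(=O)N(S(=O)(=O)O)[C@@H]1Cn1ncnc1CN)c1csc(N)n1)C(=O)O` gives > 37 h, which is a limit of the assay and not a number.

Among the two plain numbers, compound 1 stands at the lower one, with compound 2 the nearest: a 1.4-fold higher number from compound 1 to compound 2 (0.16 log units; within the scatter). The step from compound 1 to compound 3 cannot be sized, since the value of compound 3 is only a limit (the limit of > 37 h in this assay, at which 1 of the 3 values shown sits).

The unmeasured compound 4 `CC(C)(O/N=C(\C(=O)N[C@@H]1C(=O)N(S(=O)(=O)O)[C@@H]1Cn1ncnc1CNC(=N)N)c1csc(N)n1)C(=O)O` differs from compound 1 in one place: a group of 10 heavy atoms (4 carbon, 6 nitrogen; one five-membered aromatic ring with 3 hetero atoms) in place of a group of 5 heavy atoms (2 carbon, 2 nitrogen, 1 oxygen; no ring), on a saturated chain carbon bound to a saturated ring carbon.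

For the measured compounds named here, two measured steps bear on this change. The exchange of the glycinamide side chain for a ring-bearing group in compound 3 left no readable step, and the exchange for 2-oxopiperidin-1-yl in compound 2 gave a step within the scatter. Nothing shown therefore points to a step beyond the scatter in this assay in either direction for compound 4. The expected step is a 1.0-fold higher number from compound 1 to compound 4 (0.00 log units; within the scatter). Compound 4 is estimated at 150 h, with a range from 60 h to 350 h.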

Compound 4, half-life: > 37 h
Compound 4: a limit, no number; the forecaster's own chance of this, stated with the estimate: 30%; the middle value lies beyond the limit too.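

The result for compound 4 is a limit and not a number, so its steps from compound 1, compound 2 and compound 3 cannot be read: the limit of > 37 h in this assay, at which 2 of the 4 values shown sit. The compounds shown leave open where compound 3 and compound 4 really stand in this assay, and whether the group replacing a hydrogen atom on an amine nitrogen in compound 4 changes the half-life at all.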